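The compounds below may be only part of what the source reports. "The series", "measured", "known", "first", "only" and "open" are said of these compounds alone.

Compound 1 `O=[N+]([O-])c1ccc(O)c(/C=N/Nc2nc3ccccc3s2)c1` gives > 200 ug/mL
Compound 2 `CN(C)c1ccc(/C=N/Nc2nc3ccccc3s2)cc1` gives > 200 ug/mL
Compound 3 `Oc1cccc(/C=N/Nc2nc3ccccc3s2)c1O` gives > 200 ug/mL

These three compounds share one core and were tested in a toxicity assay on cells (Erythrocyte, Mus musculus) for activation, read by spectrophotometry and hemolysis, with a stated time of 30 min (a lower number here means that less compound is needed, a higher number that more compound is needed for the effect), for their effect on mouse red blood cells. Compound 2 gives > 200 ug/mL as its result, which is a limit of the assay and not a number. It has company there, as the whole data set comes down to one entry: the limit of > 200 ug/mL in this assay, at which 3 of the 3 values shown sit, and nothing else. The three compounds therefore cannot be ranked.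

Compound 4 `Oc1ccc(/C=N/Nc2nc3ccccc3s2)cc1` is still unmeasured. Its structure departs from compound 2 in one place: hydroxy in place of dimethylamino on an aromatic carbon describes the change, hydroxy in place of dimethylamino on an aromatic carbon, para to a large group.

Going by the values given here, no measured pair shows this change directly, so the nearest guide is the compounds that already carry hydroxy. Compound 1 has hydroxy and gives > 200 ug/mL as a limit. Compound 3 also has hydroxy and gives > 200 ug/mL as a limit. On that basis, no step beyond the scatter is expected in this assay and no direction can be favoured. The expected change is a step that the limit leaves unreadable from compound 2 to compound 4 as an estimate, and the assay will most likely report only a limit again. For compound 4 the estimate is 250 ug/mL with an expected range from 120 ug/mL to 500 ug/mL in this assay.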

Compound 4, half-maximal effective concentration: > 200 ug/mL
Compound 4 ended at the assay's limit; the forecaster's own chance of this, stated with the estimate: 85%; the middle value lies beyond the limit too.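

Compound 4 gives > 200 ug/mL in this assay, which is a limit of the assay and not a number. Compound 2 also sits at a limit, so no step can be read between compound 2 and compound 4: the limit of > 200 ug/mL in this assay, at which 4 of the 4 values shown sit.

The compounds shown leave open what concentration any of the four would need for the effect, and so how they rank.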